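From 3-bromophenyl to 4-methylphenyl: estimating compound 4

The source may report more compounds than this note shows. Statements on the series, on what has been measured and on what is new or still open speak of the compounds shown alone.

Three related compounds that share a core have been tested in an ADME assay on cells (Macrophage, Homo sapiens) for cytotoxicity, read by MTT assay, with a stated time of 24 h; a lower number here means that less compound is tolerated, a higher number that more compound is tolerated. Compound 1 `COc1ccc(/C=C/c2ncc([N+](=O)[O-])n2CC(C)O)cc1` gives 560 nM, compound 2 `CC(O)Cn1c([N+](=O)[O-])cnc1/C=C/c1cccc(F)c1` gives 1030 nM and compound 3 `CC(O)Cn1c([N+](=O)[O-])cnc1/C=C/c1cccc(Br)c1` gives 620 nM. Compound 3 is the starting point here, and neither of the other two numbers lies beyond the usual scatter from it.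

The next compound is compound 4 `Cc1ccc(/C=C/c2ncc([N+](=O)[O-])n2CC(C)O)cc1`, which has not yet been measured. It carries 4-methylphenyl in place of 3-bromophenyl, on a double-bonded chain carbon bound to a double-bonded chain carbon: 4-methylphenyl in place of 3-bromophenyl on a double-bonded chain carbon bound to a double-bonded chain carbon.

Among the measured compounds shown here, only one measured step bears on this change, and only indirectly. It is a 1.7-fold lower number from compound 2 to compound 3 (0.22 log units; within the scatter), with bromo in place of fluoro on an aromatic carbon. That step stays within the scatter, but it does not test a 4-methylphenyl group, so the data give no direct measure of this change. For the measured compounds named here, no measured compound carries that group, and the nearest guide is the small spread of the three numbers in this assay. The expected result is therefore no step beyond the scatter, with an estimated no change at the digits printed from compound 3 to compound 4 (within the scatter). For compound 4, the estimated value is 620 nM, with an expected range from 330 nM to 1150 nM.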

Compound 4, half-maximal cytotoxic concentration: 860 nM
Compound 4: the middle estimate sits 1.4-fold (0.14 log units) below what was measured; measured number inside the range.
By their numbers in this assay, from the lowest: compounds 1, 3, 4 and 2 (each within the scatter of the next).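

In this assay, placing 4-methylphenyl in place of 3-bromophenyl on a double-bonded chain carbon bound to a double-bonded chain carbon gives a 1.4-fold higher number from compound 3 to compound 4 (0.14 log units; within the scatter), so this place tolerates a change of both the ring's substituent and where it sits without a step beyond the scatter. The other two comparisons agree: 4-methylphenyl in place of 3-fluorophenyl gives a 1.2-fold lower number from compound 2 to compound 4 (0.08 log units; within the scatter), and methyl in place of methoxy on an aromatic carbon gives a 1.5-fold higher number from compound 1 to compound 4 (0.19 log units; within the scatter), so compound 4 stays within the scatter of all three earlier compounds. Nothing measured here explains why these numbers lie so close together.

Going by these compounds, all four compounds carry a phenyl ring with one substituent, from among fluoro, bromo, methyl and methoxy, so it remains open whether an amine, a carboxylic acid or a longer chain on that ring would leave the number within the same scatter. The comparison of 3-bromophenyl with 4-methylphenyl also changes two things at once, and a pair such as 3-methylphenyl and 4-methylphenyl would be needed to separate the group from its place on the ring.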